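Carboxyphenyl linker replacement in a bile acid receptor agonist series

The source may report more compounds than this note shows. Statements on the series, on what has been measured and on what is new or still open speak of the compounds shown alone.

Compound 1 `CC(C)c1onc(-c2c(Cl)cccc2Cl)c1COc1ccc(N(C)Cc2ccc(C(=O)NS(C)(=O)=O)cc2)c(C(F)(F)F)n1` gives 221 nM in a functional assay on HEK293 cells for agonist activity at Bile acid receptor (Homo sapiens); on this read-out lower numbers stand for an effect already at smaller amounts and higher numbers for an effect only at larger amounts of compound. Compound 2 `CC(Nc1ccc(C(=O)O)cc1)c1ccc(OCc2c(-c3c(Cl)cccc3Cl)noc2C2CC2)nc1C(F)(F)F` gives 333 nM. Compound 3 `CC(c1ccc(OCc2c(-c3c(Cl)cccc3Cl)noc2C2CC2)nc1C(F)(F)F)N(C)c1ccc(C(=O)O)cc1` gives 208 nM.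

Compound 2 carries the highest of the three numbers, but its gap to compound 1 and the step of a 1.6-fold lower number from compound 2 to compound 3 (0.20 log units; within the scatter) both lie within the scatter, so the three compounds cannot be ordered. Compound 4 `O=C(O)c1cccc(OCc2ccc(OCc3c(-c4c(Cl)cccc4Cl)noc3C3CC3)nc2C(F)(F)F)c1` differs from compound 2 by (3-carboxyphenoxy)methyl in place of 1-((4-carboxyphenyl)amino)ethyl on an aromatic carbon. Among the compounds with values here, no measured step covers this change: the one measured step, from compound 2 to compound 3, concerns only a methyl on nitrogen, and compound 1 differs from both in several places at once. The direction of the step therefore cannot be read from the data, and the expectation is a step of a 1.2-fold higher number from compound 2 to compound 4 (0.08 log units; within the scatter) that stays near the scatter, with a wide range. Compound 4 is estimated at 400 nM, between 130 nM and 1300 nM.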

Compound 4, half-maximal effective concentration: 151 nM
For compound 4 the middle estimate is 2.6-fold (0.42 log units) above the measured one; measured number inside the range.
By their numbers in this assay, from the lowest: compounds 4, 3, 1 and 2 (each within the scatter of the next, the first and the last beyond it).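

Within the data shown here, on the aromatic carbon ortho to a trifluoromethyl group, the change to (3-carboxyphenoxy)methyl gives a 2.2-fold lower number from compound 2 to compound 4 (0.34 log units; beyond the scatter) in this assay and is the first step to clear the scatter. The whole side chain changes at once, so the linking atoms and the place of the carboxylic acid on the benzene ring cannot be separated. No evidence at hand explains this step.

Open, from the compounds shown here alone, is which part of the new side chain carries the lower number, and whether a tetrazole in place of the carboxylic acid of compound 4 keeps it.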